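Series notes: 4-fluorophenyl to phenyl

The compounds below may be only part of what the source reports. "The series", "measured", "known", "first", "only" and "open" are said of these compounds alone.

Values in an ADME assay on HepG2 cells (Homo sapiens) for cytotoxicity, read by MTT assay, with a stated time of 72 h (on this read-out lower numbers stand for higher toxicity in this test and higher numbers for lower toxicity in this test), for the compounds measured so far
compound 1 `CC(C)(C)Nc1nc2cc(-c3ccc(Br)cc3)sc2c(=O)[nH]1` gives 1400 nM
compound 2 `CC(C)(C)Nc1nc2cc(-c3ccc(F)cc3)sc2c(=O)[nH]1` gives 5100 nM
compound 3 `CC(C)Nc1nc2cc(-c3ccc(F)cc3)sc2c(=O)[nH]1` gives > 25000 nM

Compound 3 gives > 25000 nM as a limit of the assay and not as a number. Of the two actual numbers, compound 2 gives 5100 nM as the higher one, and compound 1 is its nearest neighbour.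

Compound 4 `CC(C)(C)Nc1nc2cc(-c3ccccc3)sc2c(=O)[nH]1` has not been measured. Its difference from compound 2 is hydrogen in place of fluoro on an aromatic carbon and reads in words as hydrogen in place of fluoro on an aromatic carbon, or 4-fluorophenyl to phenyl.

The measured step at this place is a 3.6-fold higher number from compound 1 to compound 2 (0.56 log units; beyond the scatter) and it sets the expected direction, toward a higher number, though by a smaller step likely to stay within the scatter. The other measured step is an at least 4.9-fold higher number from compound 2 to compound 3 (0.69 log units; beyond the scatter) and sits on a saturated chain carbon, so it does not bear on this change. The expected step is a 1.6-fold higher number from compound 2 to compound 4 (0.20 log units; within the scatter) in this assay as an estimate only. Compound 4 is estimated at 8000 nM with an expected range from 3500 nM to 19000 nM once measured.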

Compound 4, half-maximal cytotoxic concentration: 12500 nM
Compound 4: the middle estimate sits 1.6-fold (0.19 log units) below what was measured, and the stated range covers the measured number.
By their numbers in this assay, from the lowest: compound 1; then compound 2; then compound 4. At a limit, above all of these: compound 3.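

In this assay the aromatic carbon para to a large group still responds once the halogen is gone altogether, since hydrogen in place of fluoro gives a 2.5-fold higher number from compound 2 to compound 4 (0.39 log units; beyond the scatter) and this step stands on its own beyond the scatter. Among compound 1, compound 2 and compound 4, the number rises in the order bromo, fluoro, hydrogen, with no compound going against that order, and the whole span is an 8.9-fold higher number from compound 1 to compound 4 (0.95 log units; beyond the scatter) at this single position. The earlier bromo-to-fluoro step therefore did not mark a floor for the change, and the phenyl of compound 4 sits highest of the three.

On these data alone, whether a methoxy group, an amine or a carboxylic acid at this position would fit the same order stays open, as does whether the change carries over to the amine chain of compound 3. Nothing at hand accounts for the size of these steps.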